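Three Sulfonamides at the Assay Limit, a Fourth Expected There

The source may hold more compounds than are shown below. What is called first, only, known or untested is meant among the compounds shown, and "the series" means these compounds.

In an assay on isolated protein for inhibition of malate dehydrogenase, mitochondrial (Sus scrofa), with stated times of 45 min and 30 min (on this read-out lower numbers stand for stronger inhibition and higher numbers for weaker inhibition), compound 1 `O=S(=O)(Nc1ccc(-c2nc3ccccc3o2)cc1)c1cccc(F)c1` reaches only the limit > 63000 nM.
In this assay compound 2 `O=S(=O)(Nc1ccc(-c2nc3ccccc3o2)cc1)c1cccc(C(F)(F)F)c1` reaches only the limit > 63000 nM.
In this assay compound 3 `O=S(=O)(Nc1ccc(-c2nc3ccccc3o2)cc1)c1ccc(F)cc1` reaches only the limit > 63000 nM.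

Compound 2 differs from compound 1 by trifluoromethyl in place of fluoro on an aromatic carbon, and the step that the two limits leave unreadable from compound 1 to compound 2. Compound 3 differs from compound 1 by 4-fluorophenyl in place of 3-fluorophenyl on a sulfonyl sulfur, and the step that the two limits leave unreadable from compound 1 to compound 3. Compound 4 `O=S(=O)(Nc1ccc(-c2nc3ccccc3o2)cc1)c1ccc(C(F)(F)F)cc1`, not yet measured, differs from compound 3 by trifluoromethyl in place of fluoro on an aromatic carbon, the same kind of change as that from compound 1 to compound 2, though here para to a large group rather than meta to a large group. Every value shown sits at the limit of > 63000 nM in this assay, at which 3 of the 3 values shown sit, so nothing indicates a readable step. Compound 4 is expected to give 100000 nM, between 30000 nM and 500000 nM. The expected step is a step that the limit leaves unreadable from compound 3 to compound 4, resting on compound 3 at > 63000 nM.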

Compound 4, half-maximal inhibitory concentration: > 63000 nM
Compound 4 was reported as a limit; the forecaster's own chance of this, stated with the estimate: 85%; the middle value lies beyond the limit too.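

No new step can be read, because compound 3 and compound 4 are both reported only as limits in this assay: the limit of > 63000 nM in this assay, at which 4 of the 4 values shown sit.

The compounds shown leave open how strongly any of the four inhibits, and whether swapping fluoro for trifluoromethyl changes inhibition at all.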